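The compounds below may be only part of what the source reports. "The series", "measured", "known", "first", "only" and "open" are said of these compounds alone.

Measured so far in a functional assay on U-87MG ATCC cells (Homo sapiens) for cytotoxicity, read by MTT assay, with a stated time of 72 h; on this read-out higher numbers stand for weaker inhibition and lower numbers for stronger inhibition:
compound 1 `COc1ccc(-c2cc(C(=O)Nc3ccc(Oc4ccnc5cc(OCCCN6CCCCC6)c(OC)cc45)c(F)c3)c3ccccc3n2)cc1` gives 1360 nM
compound 2 `COc1cc2c(Oc3ccc(NC(=O)c4cc(-c5cccc(Cl)c5)nc5ccccc45)cc3F)ccnc2cc1OCCCN1CCCCC1` gives 150 nM
compound 3 `COc1cc2c(Oc3ccc(NC(=O)c4cc(-c5cccc(Cl)c5)nc5ccc(F)cc45)cc3F)ccnc2cc1OCCCN1CCCC1` gives 990 nM

Compound 1 and compound 2 share one core and differ in a single place: 4-methoxyphenyl in place of 3-chlorophenyl on an aromatic carbon. In this assay this change gives a 9.1-fold higher number from compound 2 to compound 1 (0.96 log units; beyond the scatter), a step beyond the scatter, so within this pair the 3-chlorophenyl partner carries the lower number.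

Compound 3 has a different core from compound 2; the difference between the two cores is not broken down here. Its number in this assay sits beyond the scatter from that of compound 2, whose number is lower, and within the scatter of that of compound 1, so no order between compound 3 and compound 1 can be read from these two values.

Compound 4 `COc1ccc(-c2cc(C(=O)Nc3ccc(Oc4ccnc5cc(OCCCN6CCCC6)c(OC)cc45)c(F)c3)c3cc(F)ccc3n2)cc1` is not yet measured. It differs from compound 3 in one place: 4-methoxyphenyl in place of 3-chlorophenyl on an aromatic carbon. This is the same change as from compound 2 to compound 1, made on the core of compound 3 rather than on that of compound 2. Going by the values given here, the expectation for compound 4 in this assay is therefore a step of a 6.1-fold higher number from compound 3 to compound 4 (0.78 log units; beyond the scatter) from compound 3, resting on the single prior instance, a 9.1-fold higher number from compound 2 to compound 1 (0.96 log units; beyond the scatter). Among the compounds with values here, only one such instance is available, and it stands on a different core; the range is accordingly wide. Compound 4 is thus expected to give about 6000 nM in this assay, estimated to fall between 2000 nM and 20000 nM.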

Compound 4, half-maximal inhibitory concentration: 930 nM
Compound 4: middle estimate off by 6.5-fold (0.81 log units), on the high side; the measured number lies below the stated range.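

On the second core, 4-methoxyphenyl in place of 3-chlorophenyl gives a 1.1-fold lower number from compound 3 to compound 4 (0.03 log units; within the scatter) in this assay, so no order can be read within this pair, unlike the pair on the first core, where the 3-chlorophenyl partner carries the lower number. The size of the step therefore does not carry over unchanged between these two cores: the same change on two cores in this assay, a 9.1-fold higher number (0.96 log units; beyond the scatter) from compound 2 to compound 1 and a 1.1-fold lower number (0.03 log units; within the scatter) from compound 3 to compound 4, 9.7-fold (0.98 log units) apart, beyond the scatter of two such steps

Going by these compounds alone, these two pairs show only that the step depends on the core; they do not show which part of the difference between the cores matters, nor what the change would give on any further core, and with one pair per core, neither step rests on a repeat.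

Still open, as far as these compounds go, is whether the gap between the two steps follows the chlorine, the methoxy group or their places on the phenyl ring, which 4-chlorophenyl and 3-methoxyphenyl partners on both cores would help to separate. Also open, from the compounds shown here alone, is how the two cores would compare if they differed in one place only, with the fluorine on the shared ring system or the cyclic amine at the end of the propoxy chain changed on its own, and whether an unsubstituted phenyl group would follow either step.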